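The source may report more compounds than this note shows. Statements on the series, on what has been measured and on what is new or still open speak of the compounds shown alone.

Measured compounds:
Compound 1 `COc1cc(/C=C/C(C)=O)ccc1OCc1cn(-c2ccccc2CO)nn1` — in a functional assay on HCT-116 cells (Homo sapiens) for antiproliferative activity, read by MTT assay, with a stated time of 48 h (on this read-out higher numbers stand for weaker inhibition and lower numbers for stronger inhibition), compound 1 gives > 100000 nM, a limit of the assay rather than a number.
Compound 2 `COc1cc(/C=C/C(C)=O)ccc1OCc1cn(-c2ccc(NC(=O)c3ccccc3)cc2)nn1` — in this assay compound 2 gives > 100000 nM, likewise a limit, not a number.

Compound 2 stands at the limit of > 100000 nM in this assay, at which 2 of the 2 values shown sit. For the measured compounds named here, both values shown are limits, so no measured step exists between these two compounds and nothing on the size of a change can be read from them. Compound 3 `COc1cc(/C=C/C(C)=O)ccc1OCc1cn(-c2ccc(C=O)cc2)nn1` differs from compound 2 by formyl in place of benzamido on an aromatic carbon. Going by the values given here, with no measured step to lean on, the expected change in this assay is a step that the limit leaves unreadable from compound 2 to compound 3, none beyond the scatter, and most likely another limit. Compound 3 is expected at 200000 nM, in the range 50000 nM to 1000000 nM.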

Compound 3, half-maximal inhibitory concentration: 76200 nM
The estimate for compound 3 lay 2.6-fold (0.42 log units) above the measured number, within the range that was stated.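

With formyl in place of benzamido on an aromatic carbon, para to a large group, this assay gives a measured number for compound 3, 76200 nM, and shows an at least 1.3-fold lower number from compound 2 to compound 3 (0.11 log units; that floor lies within the scatter). With 4-formylphenyl in place of 2-(hydroxymethyl)phenyl on an aromatic nitrogen, the same read-out shows an at least 1.3-fold lower number from compound 1 to compound 3 (0.11 log units; that floor lies within the scatter). Both steps are floors, and the other two values are limits of the assay, not numbers: the limit of > 100000 nM in this assay, at which 2 of the 3 values shown sit.

From the compounds shown here alone, the true size of either step stays open. So does the outcome with a carboxylic acid or an amine on that aromatic carbon.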